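A Fluorine Swap on the Phenylglycine Arm

The compounds below may be only part of what the source reports. "The series", "measured", "known", "first", "only" and "open" are said of these compounds alone.

Compound 1, `COc1ccc(NS(=O)(=O)/C=C/c2c(F)c(F)c(F)c(F)c2F)cc1F`: 10000 nM
Compound 2, `COc1ccc(NS(=O)(=O)/C=C/c2c(F)c(F)c(F)c(F)c2F)cc1`: 10000 nM
Compound 3, `COc1cc(OC)c(/C=C/S(=O)(=O)Nc2ccc(OC)c(NC(C(=O)O)c3ccccc3)c2)c(OC)c1`: 75 nM

All three were tested in a functional assay on DU-145 cells (Homo sapiens) for cytotoxicity, read by trypan blue exclusion, with a stated time of 96 h; a higher number here means a weaker inhibitor, a lower number a stronger inhibitor. Compound 3 stands at the lowest number, and compound 1 and compound 2 both lie far higher, gaps well beyond the scatter. The difference between the core of compound 3 and the core of compound 2 is not broken down here. Compound 2 and compound 1 share a core and differ in one place, (fluoro in place of hydrogen on an aromatic carbon), and that step gave no change at the digits printed from compound 2 to compound 1 (within the scatter).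

Compound 4, `COc1cc(OC)c(/C=C/S(=O)(=O)Nc2ccc(OC)c(NC(C(=O)O)c3ccc(F)cc3)c2)c(OC)c1`, has not yet been measured. It differs from compound 3 by fluoro in place of hydrogen on an aromatic carbon. Among the compounds with values here, this is the same kind of change as the one from compound 2 to compound 1, but not the same: in compound 1 the new group sits ortho to a methoxy group and meta to a large group, whereas in compound 4 it sits para to a large group. The step expected for compound 4 is no change at the digits printed from compound 3 to compound 4 (within the scatter). Within the data shown here, that expectation rests on no change at the digits printed from compound 2 to compound 1 (within the scatter), the only measured example of this kind of change, which stayed within the scatter. Compound 4 is therefore expected to give about 75 nM, likely between 25 nM and 220 nM.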

Compound 4, half-maximal inhibitory concentration in the DU-145 assay: 75 nM
Compound 4: the middle estimate sits on the measured number at the digits printed; measured number inside the range.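

In the DU-145 assay, going from phenyl to 4-fluorophenyl gave no change at the digits printed from compound 3 to compound 4 (within the scatter), and in a physicochemical assay for solubility (a higher number here means a more soluble compound, a lower number a less soluble compound), the same change gave no change at the digits printed from compound 3 to compound 4 (within the scatter). In the physicochemical assay compound 3 gives 10000 ug/mL and compound 4 gives 10000 ug/mL. In the cell assay, the DU-145 assay, the swap therefore reads the same on both cores: the same change on two cores in the DU-145 assay, no change at the digits printed (within the scatter) from compound 2 to compound 1 and no change at the digits printed (within the scatter) from compound 3 to compound 4, 1.0-fold (0.00 log units) apart, within the scatter of two such steps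

Within the data shown here, this is only two pairs, with the fluoro at a different place in each, so it shows that the change carried over between these two cores but gives no general rule for other cores or other ring positions. It also says nothing about why the change leaves the number unmoved.

The compounds shown leave open whether a bigger group on the same ring, such as chloro or trifluoromethyl, would also leave the number in place. They also leave open what a methyl ester or an amide in place of the carboxylic acid would do on the core of compound 3.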